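The source may report more compounds than this note shows. Statements on the series, on what has been measured and on what is new or still open speak of the compounds shown alone.

Measured so far in a functional assay on HepG2 cells (Homo sapiens) for inhibition, read by MTT assay, with a stated time of 48 h (on this read-out higher numbers stand for weaker inhibition and lower numbers for stronger inhibition), are these compounds:

- compound 1 `c1ccc(-c2ccnc3c2c(-c2ccccc2)nn3-c2ccccc2)cc1` gives 3210 nM
- compound 2 `Clc1ccc(-c2ccnc3c2c(-c2ccccc2)nn3-c2ccccc2)cc1` gives 61100 nM
- compound 3 `O=C(C=CNc1cc(-c2ccccc2)nn1-c1ccccc1)c1ccccc1` gives 2660 nM

Compound 3 at 2660 nM sits within the scatter of compound 1 at 3210 nM and well under compound 2 at 61100 nM on this scale. The change from compound 3 to compound 4 `O=C(C=CNc1cc(-c2ccccc2)nn1-c1ccccc1)c1ccc(F)cc1` is fluoro in place of hydrogen on an aromatic carbon and turns benzoyl into (4-fluorophenyl)carbonyl, with fluoro in place of hydrogen on an aromatic carbon. Among the measured compounds shown here, only one measured step bears on it, a 19-fold higher number from compound 1 to compound 2 (1.28 log units; beyond the scatter) with chloro in place of hydrogen on an aromatic carbon. That step is large, but it is a single case, with a different group on the core of compound 1, so it points to a higher number and a smaller move is expected here. An estimated 2.3-fold higher number from compound 3 to compound 4 (0.35 log units; beyond the scatter) is therefore expected in this assay on this slender basis. The estimate for compound 4 is 6000 nM (expected range 1500 nM to 30000 nM).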

Compound 4, half-maximal inhibitory concentration: 59900 nM
Estimate against measurement, compound 4: 10-fold (1.00 log units) below; measured number above the stated range.
By their numbers in this assay, from the lowest: compounds 3 and 1 (each within the scatter of the next); then compounds 4 and 2 (each within the scatter of the next).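

In this assay, the change from benzoyl to (4-fluorophenyl)carbonyl gives a 23-fold higher number from compound 3 to compound 4 (1.35 log units; beyond the scatter), so a single fluoro, para to a large group, is enough to cause a large loss of inhibition. The earlier compounds showed a large rise only for chloro on the core of compound 1, a 19-fold higher number from compound 1 to compound 2 (1.28 log units; beyond the scatter); this second large rise in the same direction comes from a different halogen on a different scaffold, and neither step among those shown goes against the other. No measurement here explains why so small a replacement has so large an effect on this read-out.

The compounds shown leave open whether any group at this position keeps the number of compound 3 at 2660 nM, such as methyl, methoxy or an amine. They also leave open how fluoro would read on the other phenyl ring of compound 3.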